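Chloro in Place of Methyl: An Estimate for Compound 4

The source may hold more compounds than are shown below. What is called first, only, known or untested is meant among the compounds shown, and "the series" means these compounds.

Compound 1 `Cc1ccc(NC(=O)NC(=O)c2ccc(OCc3ccccc3F)cc2)cc1-c1nc2ccccc2[nH]1`: 1830 nM
Compound 2 `Cc1ccc(NC(=O)NC(=O)c2ccc(OCc3ccccc3Cl)cc2)cc1-c1nc2ccccc2[nH]1`: 21500 nM
Compound 3 `Cc1ccc(NC(=O)NC(=O)c2ccc(OCc3ccc(Cl)cc3Cl)cc2)cc1-c1nc2ccccc2[nH]1`: 2550 nM

Of the compounds shown here, three sharing one core have been measured in a functional assay on MNK45 cells (Homo sapiens) for inhibition, read by MTT assay, with a stated time of 48 h; on this read-out lower numbers stand for stronger inhibition and higher numbers for weaker inhibition. Compound 1 gives the lowest of the three numbers; compound 3 sits closest to it, and compound 2 furthest away. The measured steps all concern the benzyl ether end of the molecule: a 12-fold higher number from compound 1 to compound 2 (1.07 log units; beyond the scatter), a 1.4-fold higher number from compound 1 to compound 3 (0.14 log units; within the scatter), and an 8.4-fold lower number from compound 2 to compound 3 (0.93 log units; beyond the scatter).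

Compound 4 `O=C(NC(=O)c1ccc(OCc2ccccc2F)cc1)Nc1ccc(Cl)c(-c2nc3ccccc3[nH]2)c1` differs from compound 1 elsewhere: chloro in place of methyl on an aromatic carbon. Going by the values given here, none of the measured steps touches this part of the core, so no step bears directly on the change. In the absence of any direct precedent, the step from compound 1 to compound 4 in this assay is expected to stay within the scatter, and the estimate here is a 1.2-fold higher number from compound 1 to compound 4 (0.08 log units; within the scatter). Compound 4 is therefore expected to give about 2200 nM in this assay, with a range from 700 nM to 7000 nM.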

Compound 4, half-maximal inhibitory concentration: 870 nM
The estimate for compound 4 lay 2.5-fold (0.40 log units) above the measured number, and the stated range covers the measured number.
By their numbers in this assay, from the lowest: compound 4; then compounds 1 and 3 (each within the scatter of the next); then compound 2.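

The earlier compounds shown here all kept the methyl group, so compound 4 gives the first sign that the aromatic carbon ortho to a 1H-benzimidazol-2-yl group matters in this assay: chloro in place of methyl gives a 2.1-fold lower number from compound 1 to compound 4 (0.32 log units; beyond the scatter). The step is modest but beyond the scatter, and it exchanges one heavy atom for another with no change in the count of hydrogen-bond donors or acceptors. Nothing available accounts for the direction or size of this step.

The compounds shown carry only methyl and chloro at this carbon, so it remains open how fluoro, methoxy or an amine would compare there. Also open, going by these compounds, is whether chloro at this carbon would give a similar step with the other end of compound 2 or compound 3.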